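The source may report more compounds than this note shows. Statements on the series, on what has been measured and on what is new or still open speak of the compounds shown alone.

Compound 3 `N#CCNC(=O)[C@@H]1CN(S(=O)(=O)c2ccccc2)C[C@H]1C(=O)N1CCOCC1` carries an unsubstituted phenylsulfonyl group on the shared core. Among the measured compounds shown here, in an assay on isolated protein for inhibition of cathepsin S (Homo sapiens), read by fluorescence, with a stated time of 20 min (on this read-out lower numbers stand for stronger inhibition and higher numbers for weaker inhibition), compound 3 gives 271 nM, the highest of the three numbers measured so far. Compound 1 `N#CCNC(=O)[C@@H]1C[C@@H](S(=O)(=O)CC2CC2)C[C@H]1C(=O)N1CCOCC1` gives 230 nM in this assay; this lies within the scatter of the value of compound 3, so the two are not separated. Compound 2 `N#CC1(NC(=O)[C@@H]2C[C@@H](S(=O)(=O)c3ccccc3)C[C@H]2C(=O)N2CC3(COC3)C2)CC1` gives 3 nM in this assay, far below compound 3 and beyond the scatter; compound 2 differs from compound 3 in several places at once, so no single step can be read from that pair. Compound 4 `N#CCNC(=O)[C@@H]1CN(S(=O)(=O)c2ccccc2C(F)(F)F)C[C@H]1C(=O)N1CCOCC1` is compound 3 with one change: trifluoromethyl in place of hydrogen on an aromatic carbon. For the measured compounds named here, no measured pair in the set reports this change, so there is no direct precedent for it. A modest step in this assay is expected, toward a lower number, of the size a 2.3-fold lower number from compound 3 to compound 4 (0.35 log units; beyond the scatter), though an outcome within the scatter would not be surprising. Compound 4 is estimated at 120 nM in this assay, with a range from 30 nM to 500 nM.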

Compound 4, half-maximal inhibitory concentration: 18 nM
Estimate against measurement, compound 4: 6.7-fold (0.82 log units) above; the whole stated range lies above it.
By their numbers in this assay, from the lowest: compound 2; then compound 4; then compounds 1 and 3 (each within the scatter of the next).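

In this assay, trifluoromethyl in place of hydrogen on an aromatic carbon, ortho to a large group, gives a 15-fold lower number from compound 3 to compound 4 (1.18 log units; beyond the scatter) and this counts as a large step. Among the compounds shown here, the earlier compounds isolated no change on this aromatic ring, and this pair is the first to show that the ring tolerates substitution here and that a single group can shift the number well beyond the scatter. Nothing measured in the set speaks to the origin of this step.

As far as these compounds go, whether methyl, chlorine, methoxy or an amine on the same aromatic carbon would give a step of similar size remains open. Also open, from the compounds shown here alone, is whether trifluoromethyl on the phenyl ring of compound 2 would give a comparable step on that different core.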